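A few compounds are considered here, and "the series" means these few. Any claim that something is new, unique, unknown or untested is made for them only; others in the source may bear on it.

Compound 1 `CCOC(=O)/C=C1/C(=O)N2[C@@H]1SC(C)(C)[C@@H]2C(=O)OC(c1ccccc1)c1ccccc1` is the starting point of this account. Among the compounds with values here, in a functional assay on OE19 cells (Homo sapiens) for cytotoxicity, read by MTT assay, with a stated time of 48 h (on this read-out higher numbers stand for weaker inhibition and lower numbers for stronger inhibition), compound 1 gives 11200 nM, the lowest of the three numbers measured so far. Compound 2 `CC1(C)S[C@@H]2/C(=C\C(=O)OC(c3ccccc3)c3ccccc3)C(=O)N2[C@H]1C(=O)OC(c1ccccc1)c1ccccc1` gives 21600 nM in this assay, a number that falls within the usual scatter of repeated measurements relative to compound 1, so the two cannot be ordered against each other. Compound 3 `CC1(C)[C@H](C(=O)OC(c2ccccc2)c2ccccc2)N2C(=O)/C(=C/C(=O)c3ccc([N+](=O)[O-])cc3)[C@H]2S1(=O)=O` gives 95500 nM in this assay, a number that lies beyond the scatter relative to compound 1 and is the highest of the three.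

The compound that follows is compound 4 `CC1(C)S[C@@H]2/C(=C\C(=O)c3ccco3)C(=O)N2[C@H]1C(=O)OC(c1ccccc1)c1ccccc1`. Against compound 1 it differs in one place: furan-2-yl in place of ethoxy on a carbonyl carbon. Within the data shown here, no pair of measured compounds differs in exactly this one place, so there is no measured step to lean on, and the data give no direct guide to the direction of the change. Under that uncertainty compound 4 is expected to stay near compound 1, with an expected step of a 1.1-fold higher number from compound 1 to compound 4 (0.03 log units; within the scatter) that does not go beyond the scatter in either direction. The estimate for compound 4 in this assay is 12000 nM, with a range from 4000 nM to 40000 nM.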

Compound 4, half-maximal inhibitory concentration: 54300 nM
Beside the measured number, compound 4's estimate is 4.5-fold (0.66 log units) below it; the whole stated range lies below it.
By their numbers in this assay, from the lowest: compounds 1 and 2 (each within the scatter of the next); then compounds 4 and 3 (each within the scatter of the next).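

In this assay, putting furan-2-yl in place of ethoxy on a carbonyl carbon gives a step of a 4.8-fold higher number from compound 1 to compound 4 (0.69 log units; beyond the scatter) that lies beyond the usual scatter, so the number at this position does respond to the group placed there, and it moves here toward weaker inhibition. Within the data shown here, this is the first single-place change in the account that can be read at all, and it shows that ethoxycarbonyl and (furan-2-yl)carbonyl are not interchangeable on this read-out, although the step is only modest in size. No supporting data bear on this step, so the reason for the rise remains unexplained.

The compounds shown leave open whether the rise follows from the furan-2-yl ring itself or simply from the loss of ethoxy from the carbonyl carbon. Going by these compounds, how a phenyl, a methyl, an amine or a longer alkoxy chain on the same carbonyl carbon would read in this assay also remains open, and such groups could separate these two possibilities.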